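Methoxy for methyl on the aryl ring: expected inhibition

This account rests on a few compounds, and the source may have more. Where it says the series, first, only, none or still open, it means among the compounds named here.

Of the compounds shown here, three built on one shared core have been tested in a functional assay on HepG2 cells (Homo sapiens) for inhibition, read by MTT assay, with a stated time of 72 h; on this read-out higher numbers stand for weaker inhibition and lower numbers for stronger inhibition. Compound 1 `Cc1ccc(-n2cc(CNC(=O)c3cccc4c3cnn4C(C)C)nn2)c(C)c1` carries a 2,4-dimethylphenyl group on an aromatic nitrogen. In this assay compound 1 reaches only the limit > 40000 nM. Compound 2 `CC(C)n1ncc2c(C(=O)NCc3cn(-c4cccc(Br)c4)nn3)cccc21` carries a 3-bromophenyl group there. In this assay compound 2 likewise reaches only the limit > 40000 nM. Compound 3 `Cc1ccc(-n2cc(CNC(=O)c3cccc4c3cnn4C(C)C)nn2)cc1` carries a 4-methylphenyl group. In this assay compound 3 gives only the limit > 40000 nM. Because all three sit at the limit of > 40000 nM in this assay, at which 3 of the 3 values shown sit, the steps a step that the two limits leave unreadable from compound 1 to compound 2, a step that the two limits leave unreadable from compound 1 to compound 3 and a step that the two limits leave unreadable from compound 2 to compound 3 cannot be sized; none shows a readable change. Compound 4 `COc1ccc(-n2cc(CNC(=O)c3cccc4c3cnn4C(C)C)nn2)cc1` is yet to be measured; it differs from compound 3 by methoxy in place of methyl on an aromatic carbon. Since every measured variation of the aryl group on the aromatic nitrogen stayed at the limit, compound 4 is expected to stay there too, a step that the limit leaves unreadable from compound 3 to compound 4. Compound 4 is therefore estimated at 45000 nM, within 20000 nM to 120000 nM.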

Compound 4, half-maximal inhibitory concentration: > 40000 nM
Compound 4: only a limit was reported (the forecaster's own chance of this, stated with the estimate: 85%); the middle value is on the limit's open side.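

Compound 4 also gives only a limit, so its steps from compound 1, compound 2 and compound 3 cannot be read; all four compounds stand together: the limit of > 40000 nM in this assay, at which 4 of the 4 values shown sit. The compounds shown leave open which change, if any, would give a measurable value in this assay.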